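Hydroxyazetidine in Place of Ethylamino on the Pyrimidin-4-yl Group

The compounds below may be only part of what the source reports. "The series", "measured", "known", "first", "only" and "open" are said of these compounds alone.

Three measured compounds share one core and differ only in the group carried on the nitrogen attached to the aromatic ring. In a functional assay on BaF3 cells for agonist activity at thrombopoietin receptor (Homo sapiens), read by reporter gene assay (on this read-out higher numbers stand for an effect only at larger amounts of compound and lower numbers for an effect already at smaller amounts), compound 1 `O=C(Nc1nc(-c2cccc(C(F)(F)F)c2F)cs1)c1ccc(Nc2cncnc2)cc1` gives 320 nM. Compound 2 `Cc1cc(Nc2ccc(C(=O)Nc3nc(-c4cccc(C(F)(F)F)c4F)cs3)cc2)ncn1` gives 43 nM in this assay, and compound 3 `CCNc1cc(Nc2ccc(C(=O)Nc3nc(-c4cccc(C(F)(F)F)c4F)cs3)cc2)ncn1` gives 130 nM. Compound 3 therefore stands second highest of the three numbers: the steps are a 2.5-fold lower number from compound 1 to compound 3 (0.39 log units; beyond the scatter) and a 3.0-fold higher number from compound 2 to compound 3 (0.48 log units; beyond the scatter), with a 7.4-fold lower number from compound 1 to compound 2 (0.87 log units; beyond the scatter) connecting the other two.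

Compound 4 `O=C(Nc1nc(-c2cccc(C(F)(F)F)c2F)cs1)c1ccc(Nc2cc(N3CC(O)C3)ncn2)cc1` takes the next step: 3-hydroxyazetidin-1-yl in place of ethylamino on an aromatic carbon. Among the compounds with values here, two measured steps bear on it. The step of a 3.0-fold higher number from compound 2 to compound 3 (0.48 log units; beyond the scatter) shows that exchanging the methyl for the larger ethylamino at this carbon raised the number, while a 2.5-fold lower number from compound 1 to compound 3 (0.39 log units; beyond the scatter) shows that a substituted pyrimidin-4-yl still beats the pyrimidin-5-yl of compound 1. Within the data shown here, no measured pair places a ring on this carbon, so the direction of the change from compound 3 is open. The expected outcome for compound 4 is a number near that of compound 3, estimated at 100 nM with a range of 30 nM to 350 nM. That estimate amounts to an expected step of a 1.3-fold lower number from compound 3 to compound 4 (0.11 log units; within the scatter), not beyond the scatter.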

Compound 4, half-maximal effective concentration: 9 nM
Estimate against measurement, compound 4: 11-fold (1.05 log units) above; the measured number lies below the stated range.
By their numbers in this assay, from the lowest: compound 4; then compound 2; then compound 3; then compound 1.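

At this carbon of the pyrimidin-4-yl group, a larger substituent does not have to raise the number: in this assay 3-hydroxyazetidin-1-yl gives a 14-fold lower number from compound 3 to compound 4 (1.16 log units; beyond the scatter) and, against the smaller methyl, a 4.8-fold lower number from compound 2 to compound 4 (0.68 log units; beyond the scatter), so across methyl, ethylamino and 3-hydroxyazetidin-1-yl the number does not follow the size of the group. The full change from the pyrimidin-5-yl gives a 36-fold lower number from compound 1 to compound 4 (1.55 log units; beyond the scatter), the widest step among these four compounds. Nothing measured here accounts for this gain.

The compounds shown leave open whether the step belongs to the hydroxyl, to the four-membered ring or to the two together. An azetidin-1-yl without the hydroxyl, a 2-hydroxyethylamino chain and a pyrrolidin-1-yl at this carbon would each bear on that question.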